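Amide aryl exchange on the dimethylamino analogue

The compounds below may be only part of what the source reports. "The series", "measured", "known", "first", "only" and "open" are said of these compounds alone.

Two compounds carry the shared core. Among the compounds with values here, in a functional assay on A549 cells (Homo sapiens) for antiproliferative activity, read by MTT assay, with a stated time of 72 h (on this read-out lower numbers stand for stronger inhibition and higher numbers for weaker inhibition), compound 1 `COc1cc(F)c(NC(=O)c2ccnc(Cl)c2)cc1Nc1nccc(-c2cn(C)c3ccccc23)n1` gives 6890 nM and compound 2 `COc1cc(N(C)C)c(NC(=O)c2ccnc(Cl)c2)cc1Nc1nccc(-c2cn(C)c3ccccc23)n1` gives 3430 nM; the only step between them, a 2.0-fold lower number from compound 1 to compound 2 (0.30 log units; within the scatter), has dimethylamino in place of fluoro on an aromatic carbon, so the two numbers stand within the scatter of each other and compound 2 is not set apart from compound 1.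

Compound 3 `COc1cc(N(C)C)c(NC(=O)c2ccccn2)cc1Nc1nccc(-c2cn(C)c3ccccc23)n1` is not yet measured. It differs from compound 2 by pyridin-2-yl in place of 2-chloropyridin-4-yl on a carbonyl carbon. Within the data shown here, no measured step touches the carbonyl-attached ring; the single step in the set concerns another position and stays within the scatter. There is therefore no basis in these two values for expecting a step in this assay beyond the scatter in either direction, only a wide uncertainty.

Compound 3 is estimated at 3500 nM, in a range from 900 nM to 14000 nM, which means an expected step of a 1.0-fold higher number from compound 2 to compound 3 (0.01 log units; within the scatter).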

Compound 3, half-maximal inhibitory concentration: 8290 nM
Beside the measured number, compound 3's estimate is 2.4-fold (0.37 log units) below it; the range from low to high includes it.
By their numbers in this assay, from the lowest: compounds 2, 1 and 3 (each within the scatter of the next, the first and the last beyond it).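

Working from the shared core, the carbonyl-attached ring is the first place in this series where a single change is read beyond the scatter in this assay: pyridin-2-yl in place of 2-chloropyridin-4-yl on a carbonyl carbon gives a modest step (a 2.4-fold higher number from compound 2 to compound 3 (0.38 log units; beyond the scatter)). The earlier dimethylamino-for-fluoro step stayed within the scatter, so this position is the only one shown to respond, and 2-chloropyridin-4-yl is the better-reading group of this pair. Nothing available explains this step.

The step combines loss of the chlorine with a change in where the pyridine ring is attached, so pyridin-4-yl on the same carbonyl carbon would be needed to tell these apart. Also open, as far as these compounds go, is how an amine or a carboxylic acid on this ring would read, and whether the step holds with fluoro in place of dimethylamino.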